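A few compounds are considered here, and "the series" means these few. Any claim that something is new, unique, unknown or untested is made for them only; others in the source may bear on it.

Measured in a functional assay on MCF7 cells (Homo sapiens) for antiproliferative activity, read by MTT assay, with a stated time of 48 h; a lower number here means a stronger inhibitor, a higher number a weaker inhibitor:
- compound 1 `COc1cccc(C(=O)Nc2nnc(/C=C/c3cc(OC)c(OC)c(OC)c3Br)s2)c1`: 170 nM
- compound 2 `COc1cc(/C=C/c2nnc(NC(=O)c3ccc(Cl)cc3)s2)c(Br)c(OC)c1OC`: 280 nM

Not yet measured:
- compound 3 `COc1cccc(C(=O)Nc2nnc(/C=C/c3cc(OC)c(OC)c(OC)c3)s2)c1`

For the measured compounds named here, only two numbers are available in this assay. Compound 1, at 170 nM, lies within the scatter of compound 2, so the pair cannot be ranked.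

The next step is from compound 1 to compound 3: hydrogen in place of bromo on an aromatic carbon. In words, this is hydrogen in place of bromo on an aromatic carbon.

Going by the values given here, the only measured step, a 1.6-fold higher number from compound 1 to compound 2 (0.22 log units; within the scatter), is 4-chlorophenyl in place of 3-methoxyphenyl on a carbonyl carbon. Among the compounds with values here, both of its compounds keep the bromo, so it shows only that one change elsewhere stayed within the scatter. Within the data shown here, no measured compound lacks the bromo, and the data therefore give neither the size nor the direction of this step directly.

A small move toward a higher number in this assay is tentatively expected, not clearly beyond the scatter, with wide uncertainty. The estimate corresponds to an expected 1.8-fold higher number from compound 1 to compound 3 (0.25 log units; within the scatter). For compound 3 the expected value is 300 nM, with an estimated range of 80 nM to 1100 nM.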

Compound 3, half-maximal inhibitory concentration: 480 nM
Compound 3: middle estimate off by 1.6-fold (0.20 log units), on the low side; the measured number falls inside the stated range.
By their numbers in this assay, from the lowest: compounds 1, 2 and 3 (each within the scatter of the next, the first and the last beyond it).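

Replacing the bromo with hydrogen on the aromatic carbon ortho to a large group gives a 2.8-fold higher number from compound 1 to compound 3 (0.45 log units; beyond the scatter) in this assay and is the only step shown that lies beyond the scatter. The earlier step, a 1.6-fold higher number from compound 1 to compound 2 (0.22 log units; within the scatter), changed the group on the carbonyl carbon and kept the bromo, so it said nothing about this position; this pair shows that, with the 3-methoxyphenyl group held constant, the bromo position does register in the read-out, though only modestly. No supporting measurement bears on why the number moves with this change, so the step stands as an observation without an explanation.

Whether the effect belongs to bromine specifically or to any group at this carbon stays open, as the series shown holds only bromo and hydrogen here and nothing such as chloro, fluoro, methyl or an amine. Also open is whether the step keeps its size with the 4-chlorophenyl group on the carbonyl carbon, as the hydrogen-for-bromo change is shown in a single pair.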